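The source may hold more compounds than are shown below. What is called first, only, known or untested is meant among the compounds shown, and "the series" means these compounds.

Measured so far in an assay on isolated protein for inhibition of DNA topoisomerase 1 (Homo sapiens), with a stated time of 30 min, tested at 20 uM; on this read-out lower numbers stand for a weaker effect and higher numbers for a stronger effect at the one concentration tested:
- compound 1 `Oc1cccc(-c2cc(-c3cccs3)cc(-c3ccccc3O)n2)c1`: 1.5%
- compound 2 `Oc1cccc(-c2cc(-c3cccs3)cc(-c3cccc(O)c3)n2)c1`: 0%
- compound 3 `Oc1cccc(-c2cc(-c3ccoc3)cc(-c3ccccc3O)n2)c1`: "not determined" (no result reported)

Compound 1 and compound 2 share a core and differ in one place; the change 3-hydroxyphenyl in place of 2-hydroxyphenyl on an aromatic carbon gives a number 1.5 percentage points lower from compound 1 to compound 2 (within the scatter). Both values sit at the bottom of the read-out, so the pair shows no usable effect of that change at the concentration tested.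

Compound 3 differs from compound 1 by furan-3-yl in place of thiophen-2-yl on an aromatic carbon; this is the difference between the two cores. For compound 3 this assay returned no result, so nothing measured anchors the second branch of the series.

Compound 4 `Oc1cccc(-c2cc(-c3ccoc3)cc(-c3cccc(O)c3)n2)c1` is yet to be measured in this assay. It differs from compound 3 by 3-hydroxyphenyl in place of 2-hydroxyphenyl on an aromatic carbon. This is the same kind of change as that from compound 1 to compound 2, but not the same: in the first pair the place is meta to a thiophen-2-yl group, whereas here it is meta to a furan-3-yl group. Among the measured compounds shown here, the only measured step of this kind lies within the scatter, and the two anchoring values of compound 1 and compound 2 are both close to zero, so the expectation for compound 4 rests on the assumption that exchanging the two hydroxyphenyl groups again moves little.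

Compound 4 is expected to give 2% in this assay, with a likely range from 0% to 12%, on the basis that compound 2 gives 0% after the same kind of change.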

Compound 4, a percentage reported as inhibition, at one concentration (the size of the read-out at that concentration, not a potency): 2%
Compound 4: the middle estimate sits on the measured number at the digits printed, and the stated range covers the measured number.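

In this assay, the exchange of thiophen-2-yl for furan-3-yl can be read once: a number 2 percentage points higher from compound 2 to compound 4 (within the scatter), so on the core of compound 2 this change shows no effect beyond the scatter. This is a single pair with both values at the bottom of the read-out, so it shows that the change does not lift the read-out on this core at the concentration tested, but not that the change is neutral on a core with a clear effect to lose. Compound 3 has no result, so the steps that touch it cannot be read, the exchange remains unseen on the core of compound 1, and carrying either change from one core to another stays untested, with no supporting measurement available on what lies behind these values.

The compounds shown leave open whether any member of this series gives a read-out clear of the bottom in this assay, which any judgement of these two changes would need. They also leave open what an amine or a carboxylic acid in place of a hydroxyl group, or a longer chain on the furan or thiophene ring, would give.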